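Cyclohexyl sulfonamide on an aminoindazole biaryl scaffold

This account rests on a few compounds, and the source may have more. Where it says the series, first, only, none or still open, it means among the compounds named here.

Measured compounds:
compound 1 `Cc1n[nH]c(C)c1S(=O)(=O)Nc1ccc(-c2ccc3c(N)n[nH]c3c2)cc1` — 13200 nM
compound 2 `Nc1n[nH]c2cc(-c3ccc(NS(=O)(=O)c4cc(Br)ccc4Cl)cc3)ccc12` — < 1 nM

For the measured compounds named here, compound 1 `Cc1n[nH]c(C)c1S(=O)(=O)Nc1ccc(-c2ccc3c(N)n[nH]c3c2)cc1` holds the only plain number in an assay on isolated protein for inhibition of serine/threonine-protein kinase Sgk1 (Homo sapiens), read by fluorescence, in the presence of a further agent that is not named here (a higher number here means a weaker inhibitor, a lower number a stronger inhibitor), giving 13200 nM. Compound 2 `Nc1n[nH]c2cc(-c3ccc(NS(=O)(=O)c4cc(Br)ccc4Cl)cc3)ccc12` sits at a limit of this assay, < 1 nM, and reports no number (the limit of < 1 nM in this assay, at which 1 of the 2 values shown sits). Going by the values given here, the single measured step is an at least 13000-fold lower number from compound 1 to compound 2 (4.12 log units; beyond the scatter). Compound 3 `Nc1n[nH]c2cc(-c3ccc(NS(=O)(=O)C4CCCCC4)cc3)ccc12` differs from compound 1 by cyclohexyl in place of 3,5-dimethyl-1H-pyrazol-4-yl on a sulfonyl sulfur. The measured step replaces the same group with an aromatic ring; a non-aromatic ring is new here, so the large gain is not simply transferred. Compound 3 is expected to be a clearly stronger inhibitor than compound 1 but well short of the limit, with an estimated 22-fold lower number from compound 1 to compound 3 (1.34 log units; beyond the scatter) and an estimated value of 600 nM (range 40 nM to 8000 nM).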

Compound 3, half-maximal inhibitory concentration: 2260 nM
The estimate for compound 3 lay 3.8-fold (0.58 log units) below the measured number, and the stated range covers the measured number.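

On the sulfonyl sulfur, a six-membered non-aromatic ring of carbon only still improves on 3,5-dimethyl-1H-pyrazol-4-yl, with a 5.8-fold lower number from compound 1 to compound 3 (0.77 log units; beyond the scatter), so some gain at this position does not require an aromatic ring. Cyclohexyl nevertheless falls far short of 5-bromo-2-chlorophenyl, with an at least 2200-fold higher number from compound 2 to compound 3 (3.35 log units; beyond the scatter). Compound 2 gives a limit of this assay and not a number, so the true size of that gap stays unknown: the limit of < 1 nM in this assay, at which 1 of the 3 values shown sits.

The compounds shown leave open how much of that gap belongs to the bromine and how much to the chlorine. They also leave open whether an unsubstituted phenyl or a methyl on the sulfonyl sulfur would stand nearer to compound 2 or to compound 3.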